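Swapping the sulfonamide for a phenyl sulfone

The source may hold more compounds than are shown below. What is called first, only, known or untested is meant among the compounds shown, and "the series" means these compounds.

Of the compounds shown here, three sharing one core have been measured in a functional assay on the whole organism (trachea) with Rattus norvegicus as the target; on this read-out lower numbers stand for smaller maximal responses and higher numbers for larger maximal responses. Compound 1 `CC1(C)C=C(n2ccccc2=O)c2cc(S(=O)(=O)N=[N+]=[N-])ccc2O1` gives 77.2%, compound 2 `CCNS(=O)(=O)c1ccc2c(c1)C(n1ccccc1=O)=CC(C)(C)O2` gives 87%, and compound 3 `COc1ccc(NS(=O)(=O)c2ccc3c(c2)C(n2ccccc2=O)=CC(C)(C)O3)cc1` gives 84.2%. Compound 3 sits between its neighbours, with a number 2.8 percentage points lower from compound 2 to compound 3 (within the scatter) and a number 7 percentage points higher from compound 1 to compound 3 (within the scatter), so the three numbers are indistinguishable. Compound 4 `CC1(C)C=C(n2ccccc2=O)c2cc(S(=O)(=O)c3ccccc3)ccc2O1` differs from compound 3 by phenyl in place of (4-methoxyphenyl)amino on a sulfonyl sulfur. The steps that touch the same sulfonyl sulfur, a number 7 percentage points higher from compound 1 to compound 3 (within the scatter) and a number 9.8 percentage points higher from compound 1 to compound 2 (within the scatter), all stayed within the scatter, so no step beyond the scatter is expected for compound 4 in this assay either, only a number 2.2 percentage points lower from compound 3 to compound 4 (within the scatter). Compound 4 is therefore estimated at 82%, likely between 70% and 92%.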

Compound 4, largest response reached (Emax), in percent of the reference or control that the assay uses: 88.1%
Compound 4: the middle estimate sits 6.1 percentage points below what was measured; the range from low to high includes it.
By their numbers in this assay, from the lowest: compounds 1, 3, 2 and 4 (each within the scatter of the next, the first and the last beyond it).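

A direct carbon link on the sulfonyl sulfur holds up in this assay: phenyl, which has no hydrogen-bond donor, gives a number 3.9 percentage points higher from compound 3 to compound 4 (within the scatter) and a number 1.1 percentage points higher from compound 2 to compound 4 (within the scatter), so the donor on the sulfonamide nitrogen is not needed to keep this response. The replacement of azido gives the only step beyond the scatter among these compounds, a number 10.9 percentage points higher from compound 1 to compound 4 (beyond the scatter). Nothing measured here explains that step. Going by these compounds, it remains open whether a methyl group directly on the sulfonyl sulfur would match phenyl. On these data alone, a 4-methoxyphenyl or a 4-carboxyphenyl group there is equally open.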